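Swapping a Nitrofuran for a Nitrophenyl: Expected Oral Bioavailability

A few compounds are considered here, and "the series" means these few. Any claim that something is new, unique, unknown or untested is made for them only; others in the source may bear on it.

Of the compounds shown here, two built on one shared core have been measured in an in vivo ADME assay on the whole organism (strain Sprague-Dawley) for pharmacokinetics, with Rattus norvegicus as the target, at a dose of 10 mg/kg by the oral route; on this read-out higher numbers stand for higher oral bioavailability and lower numbers for lower oral bioavailability. Compound 1 `Nc1ccc(CN2CCN(c3ccc(N4C[C@H](Cn5ccnn5)OC4=O)cc3F)CC2)cc1` gives 43.8% in this assay. Among the compounds with values here, compound 2 `O=C1O[C@@H](Cn2ccnn2)CN1c1ccc(N2CCN(Cc3ccc([N+](=O)[O-])o3)CC2)c(F)c1` gives 103% in this assay, the higher of the two numbers, and its only neighbour is compound 1, which sits well below it. Within the data shown here, the single measured step, a number 59.2 percentage points higher from compound 1 to compound 2 (beyond the scatter), shows that exchanging the group on the saturated chain carbon bound to an amine nitrogen in a ring can move the read-out a long way. Compound 3 `O=C1O[C@@H](Cn2ccnn2)CN1c1ccc(N2CCN(Cc3cccc([N+](=O)[O-])c3)CC2)c(F)c1` is not yet measured; it differs from compound 2 by 3-nitrophenyl in place of 5-nitrofuran-2-yl on a saturated chain carbon bound to an amine nitrogen in a ring. Among the measured compounds shown here, only that one large step bears on this change, and it concerns a different pair of groups, so the direction is uncertain. A moderate downward step of a number 33 percentage points lower from compound 2 to compound 3 (beyond the scatter) is expected for compound 3. The estimate for compound 3 in this assay is 70%, with a range from 35% to 105%.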

Compound 3, oral bioavailability: 61.5%
Beside the measured number, compound 3's estimate is 8.5 percentage points above it; measured number inside the range.
By their numbers in this assay, from the lowest: compound 1; then compound 3; then compound 2.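

In this assay, replacing 5-nitrofuran-2-yl with 3-nitrophenyl on the saturated chain carbon bound to an amine nitrogen in a ring gives a number 41.5 percentage points lower from compound 2 to compound 3 (beyond the scatter), so having a nitro group on the aromatic ring in both compounds does not keep the read-out at the same level. The 3-nitrophenyl group still stands clear of 4-aminophenyl, with a number 17.7 percentage points higher from compound 1 to compound 3 (beyond the scatter), which gives three separate levels for the three groups at this place, with 5-nitrofuran-2-yl at the top. Nothing available explains these differences.

The compounds shown leave open how much of the gap between compound 1 and compound 3 comes from the kind of substituent and how much from where it sits on the ring. A 3-aminophenyl group at this place would help separate those two changes.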